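From trifluoromethoxy to 1,1-difluoroethyl on the shared core

The source may hold more compounds than are shown below. What is called first, only, known or untested is meant among the compounds shown, and "the series" means these compounds.

- Compound 1 `CS(=O)(=O)Nc1ccc(CNC(=O)c2ccc(N3CCCC3)cc2)c(Cl)c1` in an ADME assay on microsomes from liver (Rattus norvegicus, strain Sprague-Dawley) for metabolic stability, read by HPLC, using NADPH, with stated times of 5 min and 60 min, tested at 10 uM; a higher number here means faster removal of the compound, a lower number slower removal: 17 mL.min-1.g-1
- Compound 2 `CS(=O)(=O)Nc1ccc(CNC(=O)c2ccc(OC(F)(F)F)cc2)c(Cl)c1` in this assay: 9.1 mL.min-1.g-1

On these two numbers, compound 2 stands level with compound 1 within the scatter. Compound 3 `CC(F)(F)c1ccc(C(=O)NCc2ccc(NS(C)(=O)=O)cc2Cl)cc1` differs from compound 2 as follows: 1,1-difluoroethyl in place of trifluoromethoxy on an aromatic carbon. Within the data shown here, only one measured step bears on this change, and it was also made on an aromatic carbon: a 1.9-fold lower number from compound 1 to compound 2 (0.27 log units; within the scatter). That step replaced a different pair of groups, so it is only a loose guide, but it gives no reason to expect a change beyond the scatter in this assay. The expected step is a 1.2-fold higher number from compound 2 to compound 3 (0.08 log units; within the scatter). For compound 3 the estimated value is 11 mL.min-1.g-1, with an expected range of 5.5 mL.min-1.g-1 to 22 mL.min-1.g-1.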

Compound 3, intrinsic clearance in microsomes: 9.6 mL.min-1.g-1
Estimate against measurement, compound 3: 1.1-fold (0.06 log units) above, and the stated range covers the measured number.
By their numbers in this assay, from the lowest: compounds 2, 3 and 1 (each within the scatter of the next).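

In this assay the 1,1-difluoroethyl group takes the place of trifluoromethoxy on the shared core with a 1.1-fold higher number from compound 2 to compound 3 (0.02 log units; within the scatter) and so leaves the read-out level at this position. Set against the ring-bearing pyrrolidin-1-yl group, the same change gives a 1.8-fold lower number from compound 1 to compound 3 (0.25 log units; within the scatter) and so all three groups at this place stand within the scatter of one another. No measurement shown here offers an explanation for this result. The compounds shown leave open whether a carboxylic acid or a longer alkyl chain at this place would move the number beyond the scatter.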